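The compounds below may be only part of what the source reports. "The series", "measured", "known", "first", "only" and "open" are said of these compounds alone.

Compound 1 `CCOc1cc(NC(=O)CCCCC(=O)Nc2cc(-c3ccc(C)s3)ccc2N)cc2c1OCC([N+](=O)[O-])=C2` gives 2940 nM in a functional assay on K562 cells (Homo sapiens) for antiproliferative activity, read by MTT assay, with a stated time of 48 h; on this read-out lower numbers stand for stronger inhibition of growth and higher numbers for weaker inhibition of growth.
Compound 2 `CCOc1cc(NC(=O)CCCCCNC(=O)CCCc2ccccc2)cc2c1OCC([N+](=O)[O-])=C2` gives 3320 nM in this assay.
Compound 3 `CCOc1cc(NC(=O)CCCCCCC(=O)Nc2cc(-c3ccccc3)ccc2N)cc2c1OCC([N+](=O)[O-])=C2` gives 2000 nM in this assay.

The three compounds share a core and differ only in the chain that leaves the amide. Compound 2 gives the highest of the three numbers in this assay, but its gap to compound 1 and its gap to compound 3 both lie within the usual scatter of repeated measurements, so the three are not separated by these data. Among the measured compounds shown here, no single-place step between two measured compounds is available.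

Compound 4 `CCOc1cc(NC(=O)CCCCCC(=O)Nc2ccccc2N)cc2c1OCC([N+](=O)[O-])=C2` is the next compound. It differs from compound 2 in one place: (2-aminophenyl)carbamoyl in place of ((3-phenylpropyl)carbonyl)amino on a saturated chain carbon, five bonds along the chain from a carbonyl carbon. The end group entering compound 4 is the same type of terminus found in compound 3, which gives 2000 nM in this assay, and in compound 1, which gives 2940 nM in this assay.

Because compound 3 gives 2000 nM and compound 1 gives 2940 nM in this assay, the step of a 1.3-fold lower number from compound 2 to compound 4 (0.12 log units; within the scatter) is expected to be small, toward a somewhat lower number, and probably within the scatter. For compound 4 the estimate in this assay is 2500 nM, with a range from 1000 nM to 6500 nM.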

Compound 4, concentration for 50% growth inhibition: 3960 nM
Estimate against measurement, compound 4: 1.6-fold (0.20 log units) below; the measured number falls inside the stated range.
By their numbers in this assay, from the lowest: compounds 3, 1, 2 and 4 (each within the scatter of the next).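

In this assay, among the compounds shown here, putting (2-aminophenyl)carbamoyl in place of ((3-phenylpropyl)carbonyl)amino on a saturated chain carbon, five bonds along the chain from a carbonyl carbon, gives a 1.2-fold higher number from compound 2 to compound 4 (0.08 log units; within the scatter), the first step in this set that can be read at a single place. At this position, then, the two end groups are not separated by the data, although the group that leaves has 1 hydrogen-bond donor and 1 hydrogen-bond acceptor and the group that enters has 2 of each, and one ends in a plain phenyl ring while the other carries an amino-bearing ring attached through the amide. No measurement of any property of either end group accompanies this result, so the data offer no account of it.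

The compounds shown leave open whether a carboxylic acid or a hydroxamic acid as the end group at this position would give a number beyond the scatter. They also leave open whether a longer chain carrying the same (2-aminophenyl)carbamoyl end group, or a methoxy group in place of the ethoxy group on the shared core, would do so.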